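Trading two nitro groups for a single methyl

The compounds below may be only part of what the source reports. "The series", "measured", "known", "first", "only" and "open" are said of these compounds alone.

Compound 1, `COc1ccc(C2CC(=NOC(=O)c3ccc(Br)cc3)CC(c3ccc(OC)cc3)N2C)cc1`, gives 121000 nM in a functional assay, with a stated time of 30 min; a lower number here means a stronger inhibitor, a higher number a weaker inhibitor.
Compound 2, `COc1ccc(C2CC(=NOC(=O)c3cc([N+](=O)[O-])cc([N+](=O)[O-])c3)CC(c3ccc(OC)cc3)N2C)cc1`, gives 312000 nM in this assay.
Compound 3, `COc1ccc(C2CC(=NOC(=O)c3ccc(O)cc3)CC(c3ccc(OC)cc3)N2C)cc1`, gives 25000 nM in this assay.

Compound 2 shows the highest number of the three, so it is the weakest inhibitor here: the step of a 2.6-fold higher number from compound 1 to compound 2 (0.41 log units; beyond the scatter) and the step of a 12-fold lower number from compound 2 to compound 3 (1.10 log units; beyond the scatter) both place it above the others. Compound 4, `COc1ccc(C2CC(=NOC(=O)c3ccc(C)cc3)CC(c3ccc(OC)cc3)N2C)cc1`, differs from compound 2 by 4-methylphenyl in place of 3,5-dinitrophenyl on a carbonyl carbon. Both measured steps concern the same ring on the carbonyl carbon, and in each case leaving the 3,5-dinitrophenyl gave a lower number, modest toward compound 1 and large toward compound 3. A drop of similar size is therefore expected for compound 4, estimated at 100000 nM, within 30000 nM to 300000 nM, which means an expected step of a 3.1-fold lower number from compound 2 to compound 4 (0.49 log units; beyond the scatter).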

Compound 4, half-maximal inhibitory concentration: 368000 nM
Estimate against measurement, compound 4: 3.7-fold (0.57 log units) below; the whole stated range lies below it.
By their numbers in this assay, from the lowest: compound 3; then compound 1; then compounds 2 and 4 (each within the scatter of the next).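

Leaving the 3,5-dinitrophenyl does not by itself lower the number in this assay. The change to 4-methylphenyl gives only a 1.2-fold higher number from compound 2 to compound 4 (0.07 log units; within the scatter) and so cannot be told apart from no change. Hydroxy remains the one clear gain, since methyl in place of hydroxy gives a 15-fold higher number from compound 3 to compound 4 (1.17 log units; beyond the scatter) while methyl in place of bromo gives the smaller 3.0-fold higher number from compound 1 to compound 4 (0.48 log units; beyond the scatter) on the same ring. Nothing measured here gives a reason for these differences.

Going by these compounds, whether an amine or a carboxylic acid on this ring would match the hydroxy stays open.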